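Purine series: amino for chloro on two benzyl cores

This account rests on a few compounds, and the source may have more. Where it says the series, first, only, none or still open, it means among the compounds named here.

Compound 3 `ClCc1ccc(Cn2cnc3c(Cl)nc(Cl)nc32)cc1` and compound 2 `ClCc1cccc(Cn2cnc3c(Cl)nc(Cl)nc32)c1` are built from the same atoms joined differently; the difference between the two cores is not broken down here. In a functional assay on UO-31 cells (Homo sapiens) for cytotoxicity, read by sulforhodamine B assay, with a stated time of 48 h (a lower number here means that less compound is tolerated, a higher number that more compound is tolerated), compound 3 gives 66100 nM, while compound 2 gives 5880 nM, the lowest number of the three. Compound 1 `Nc1nc(Cl)c2ncn(Cc3ccc(CCl)cc3)c2n1` carries the change (amino in place of chloro on an aromatic carbon), and in this assay compound 1 gives 55000 nM; the step is a 1.2-fold lower number from compound 3 to compound 1 (0.08 log units; within the scatter). Compound 4 `Nc1nc(Cl)c2ncn(Cc3cccc(CCl)c3)c2n1` has not been measured; it carries amino in place of chloro on an aromatic carbon, the same change placed on the core of compound 2. On the core of compound 2 this change is expected to give a 1.2-fold lower number from compound 2 to compound 4 (0.08 log units; within the scatter) in this assay, resting on the earlier step of a 1.2-fold lower number from compound 3 to compound 1 (0.08 log units; within the scatter) of the same change. In this assay compound 4 is estimated at 4900 nM, expected to fall between 2000 nM and 12000 nM.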

Compound 4, concentration lethal to 50% of the cells: 77600 nM
The estimate for compound 4 lay 16-fold (1.20 log units) below the measured number; the measured number lies above the stated range.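

On the core of compound 2, amino in place of chloro on an aromatic carbon gives a 13-fold higher number from compound 2 to compound 4 (1.12 log units; beyond the scatter) in this assay, so the step seen on the other core does not carry over: the same change on two cores in this assay, a 1.2-fold lower number (0.08 log units; within the scatter) from compound 3 to compound 1 and a 13-fold higher number (1.12 log units; beyond the scatter) from compound 2 to compound 4, 16-fold (1.20 log units) apart, beyond the scatter of two such steps. The effect of this change therefore depends on the core within this pair of cores, and a step read on one of them is no safe guide to the other. The data do not show what sets the two cores apart, and one pair per core gives no rule for any further core.

Still open, from the compounds shown here alone, is how a methylamino or methoxy group would behave in place of chloro on the same carbon of each core. Also open, going by these compounds, is whether the gap between the two steps persists when the chloromethyl group gives way to a hydroxymethyl group.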